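The compounds below may be only part of what the source reports. "The series", "measured", "known", "first", "only" and "open" are said of these compounds alone.

Measured so far:

compound 1 `CC(=O)OC1(C(=O)Nc2ccc([N+](=O)[O-])cc2)CCCCC1` – 403 nM
compound 2 `CCC(=O)OC1(C(=O)Nc2ccc([N+](=O)[O-])cc2)CCCCC1` – 14.1 nM

In a functional assay on MCF7 cells (Homo sapiens) for inhibition, read by MTT assay, with a stated time of 72 h (a higher number here means a weaker inhibitor, a lower number a stronger inhibitor), compound 1 gives 403 nM, and compound 2 gives 14.1 nM. For the measured compounds named here, compound 2 has the lowest number of the two, with compound 1 as its only neighbour on the scale; the step of a 29-fold lower number from compound 1 to compound 2 (1.46 log units; beyond the scatter) is the single measured step. The structural change in that step is a methyl in place of hydrogen on a saturated chain carbon bound to a carbonyl carbon.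

Compound 3 `O=C(Nc1ccc([N+](=O)[O-])cc1)C1(O)CCCCC1` is not yet measured. Against compound 2 it reads (hydrogen in place of propanoyl on an oxygen on a saturated carbon), or, cut one bond further out, propanoyloxy to hydroxy. Going by the values given here, no measured pair removes the ester group altogether, so the only step that bears on it is a 29-fold lower number from compound 1 to compound 2 (1.46 log units; beyond the scatter), which shows that a smaller acyl group went with a markedly higher number. Removing the acyl group entirely is expected to move further in that direction, and by a larger amount than that step, though the size is uncertain. Compound 3 is therefore expected to show a 140-fold higher number from compound 2 to compound 3 (2.15 log units; beyond the scatter) in this assay. The estimate for compound 3 is 2000 nM, within a range of 300 nM to 15000 nM.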

Compound 3, half-maximal inhibitory concentration: 664 nM
Compound 3: the middle estimate sits 3.0-fold (0.48 log units) above what was measured; measured number inside the range.
By their numbers in this assay, from the lowest: compound 2; then compounds 1 and 3 (each within the scatter of the next).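

In this assay, the low number in this set belongs to the propanoyl ester alone: replacing propanoyl with hydrogen on the oxygen gives a 47-fold higher number from compound 2 to compound 3 (1.67 log units; beyond the scatter). Acetyl on the same oxygen cannot be told apart from the free hydroxy, with a 1.6-fold higher number from compound 1 to compound 3 (0.22 log units; within the scatter). The number therefore does not fall stepwise from hydrogen through acetyl to propanoyl; only propanoyl stands apart from the other two, so an acyl group on this oxygen does not by itself give the low number. The data on hand offer no explanation for this sharp difference between acetyl and propanoyl.

On these data alone, it remains open whether a longer chain such as butanoyl, or a branched group such as isobutyryl, would keep the number low, lower it further or lose the effect, and whether an ether such as propoxy in place of propanoyloxy would behave like the ester. All three compounds also share the rest of the core, so nothing shows whether the propanoyl effect would persist with a nitrile in place of the nitro group.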